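The source may report more compounds than this note shows. Statements on the series, on what has been measured and on what is new or still open speak of the compounds shown alone.

Working notes on the series.

Compound 1, `N#CC1=C(N)OC(c2c[nH]c3ccccc23)=C(C#N)C1c1ccc(Br)cc1`, is the reference point. In a functional assay, tested at 100 ug/mL (a lower number here means a weaker effect, a higher number a stronger effect of the compound at the concentration tested), compound 1 gives 14.6%. Compound 2, `Cc1ccc(C2C(C#N)=C(N)OC(c3c[nH]c4ccccc34)=C2C#N)cc1`, gives 5.5% in this assay. Of the two numbers in hand, that of compound 1 is the one from which the other is reached by a number 9.1 percentage points lower from compound 1 to compound 2 (within the scatter); this step is within the scatter, so the two compounds are not told apart by it.

Compound 3, `N#CC1=C(N)OC(c2c[nH]c3ccccc23)=C(C#N)C1c1ccccc1Cl`, has not been measured in this assay. It differs from compound 1 as follows: 2-chlorophenyl in place of 4-bromophenyl on a saturated ring carbon. Among the compounds with values here, the only measured step that bears on it is the one from compound 1 to compound 2, which also changes a group on the aryl ring at this place and gave a number 9.1 percentage points lower from compound 1 to compound 2 (within the scatter). Within the data shown here, no measured step covers a chloro group or a 2-substituted aryl ring, so the comparison rests on one step alone. Given that the one known change at this place stayed within the scatter, the step to compound 3 is expected to be small, a number 2.6 percentage points lower from compound 1 to compound 3 (within the scatter), with no clear direction. Compound 3 is therefore estimated at 12%, with a range of 3% to 28%.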

Compound 3, a percentage reported as activity, at one concentration (the size of the read-out at that concentration, not a potency): 10.4%
Estimate against measurement, compound 3: 1.6 percentage points above, within the range that was stated.
By their numbers in this assay, from the lowest: compounds 2, 3 and 1 (each within the scatter of the next).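

In this assay, the change to 2-chlorophenyl alters both the halogen and where it sits on the aryl ring, and it gives a number 4.2 percentage points lower from compound 1 to compound 3 (within the scatter); against the 4-methylphenyl group, the same aryl ring gives a number 4.9 percentage points higher from compound 2 to compound 3 (within the scatter). With both steps within the scatter, neither a chloro group nor a 2-substituted aryl ring, both new at this saturated ring carbon, tells compound 3 apart from compound 1 or compound 2, so the three aryl groups shown cannot be ranked at this place. Nothing on hand offers an explanation for this flat picture, and the step to compound 3 cannot separate the effect of the halogen from that of its place on the ring.

Still open, going by these compounds, is whether any group on this aryl ring, such as a hydroxy group, an amine or a carboxylic acid, or a saturated cyclohexyl ring in place of the aryl ring, would give a step beyond the scatter. On these data alone, the 1H-indol-3-yl group, the amino group and the two cyano groups are the same in all three compounds, so what each contributes to the read-out remains unknown.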